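The source may hold more compounds than are shown below. What is called first, only, known or untested is meant among the compounds shown, and "the series" means these compounds.

Compound 2 (`Cc1cc(Nc2ccc(C(F)(F)F)cc2)n2nc(CCO)nc2n1`) has no exact number. In an in vitro ADME assay on microsomes from liver (Homo sapiens) for metabolic stability (on this read-out lower numbers stand for slow clearance and higher numbers for fast clearance), compound 2 gives < 5 mL.min-1.g-1, which is a limit of the assay.

The next compound, compound 4 (`CCOc1nc2nc(C)cc(Nc3ccc(C(F)(F)F)cc3)n2n1`), is built from the same atoms joined differently: ethoxy in place of 2-hydroxyethyl on an aromatic carbon. In words, it has ethoxy in place of 2-hydroxyethyl on an aromatic carbon.

Going by the values given here, no measured compound makes this exact change. The closest comparison is compound 1 (`COCc1nc2nc(C)cc(Nc3ccc(C(F)(F)F)cc3)n2n1`), which carries methoxy on its chain and gives 6.7 mL.min-1.g-1. Among the compounds with values here, the one measured step, an at least 1.3-fold lower number from compound 1 to compound 2 (0.12 log units; that floor lies within the scatter), swaps methoxy for a hydroxyl-bearing end at a different place, and its floor lies within the scatter. Compound 3 (`CCc1nc2nc(C)cc(Nc3cccc(Cl)c3)n2n1`) gives a much higher 78.3 mL.min-1.g-1, but it differs from compound 4 in more than one place, so it serves only as a loose warning that this family can reach high numbers.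

A moderate rise is therefore expected, and the estimated change is an at least 2.4-fold higher number from compound 2 to compound 4 (0.38 log units; beyond the scatter). In this assay, the estimated value for compound 4 is 12 mL.min-1.g-1, with an expected range from 5 mL.min-1.g-1 to 35 mL.min-1.g-1.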

Compound 4, intrinsic clearance in microsomes in the Homo sapiens assay: 7 mL.min-1.g-1
Beside the measured number, compound 4's estimate is 1.7-fold (0.23 log units) above it; measured number inside the range.
By their numbers in the Homo sapiens assay, from the lowest: compounds 1 and 4 (each within the scatter of the next); then compound 3. At a limit, below all of these: compound 2.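

In the Homo sapiens assay, ethoxy is the first group shown with its oxygen joined directly to this aromatic carbon, and in place of methoxymethyl it gives a 1.0-fold higher number from compound 1 to compound 4 (0.02 log units; within the scatter), so the two groups cannot be told apart on this read-out. Set against 2-hydroxyethyl in the Homo sapiens assay, ethoxy gives an at least 1.4-fold higher number from compound 2 to compound 4 (0.14 log units; that floor lies within the scatter). As far as these compounds go, in the Homo sapiens assay compound 2 gives < 5 mL.min-1.g-1, which is a limit of the assay, so the true size of that step stays unknown. In a physicochemical assay for lipophilicity, at pH 7.4 (on this read-out higher numbers stand for higher lipophilicity and lower numbers for lower lipophilicity), compound 2 gives 2.2 and compound 4 gives 3.1, and the two compounds also differ clearly here: the measured distribution coefficient of compound 2, 2.2, and of compound 4, 3.1, a number 0.90 log units higher (beyond the scatter).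

From the compounds shown here alone, whether an amine or a longer chain such as propoxy on this aromatic carbon would stay this low remains open. A single pair also cannot show whether numbers in the physicochemical assay and the Homo sapiens assay move together across this series.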